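A few compounds are considered here, and "the series" means these few. Any claim that something is new, unique, unknown or untested is made for them only; others in the source may bear on it.

Measured so far:
- compound 1 `C=CCc1cc(O)c(O)c(CN2CCC(C)CC2)c1`: 90.6%
- compound 2 `C=CCc1ccc(OCc2cn(-c3ccccc3Cl)nn2)c(O)c1`: 57.7%
- compound 3 `C#CCOc1ccc(CC=C)cc1O`: 30.3%

All three values come from a functional assay on MIA PaCa-2 cells (Homo sapiens) for inhibition, read by MTT assay, with a stated time of 72 h, tested at 50 uM; on this read-out lower numbers stand for less inhibition of growth and higher numbers for more inhibition of growth at the one concentration tested. Compound 1 stands highest of the three, and the gaps down to compound 2 and compound 3 both lie beyond the scatter.

The next compound to be tested is compound 4 `C=CCc1cc(O)c(O)c(CN2CCC(Cc3ccccc3)CC2)c1`, which keeps the core of compound 1 and changes it in one place: phenyl in place of hydrogen on a saturated chain carbon bound to a saturated ring carbon. This is phenyl in place of hydrogen on a saturated chain carbon bound to a saturated ring carbon. Cut one bond further out, the same difference reads methyl to benzyl.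

For the measured compounds named here, no two measured compounds differ in one place only, so no measured step guides the size of this change. The expectation rests on the starting point alone. With compound 1 at 90.6%, little room remains above it on this read-out, so a clear rise cannot be expected. A fall is possible, but nothing measured points to a large one. The expected change in this assay is small and downward, within the scatter, and is estimated as a number 4.6 percentage points lower from compound 1 to compound 4 (within the scatter). For compound 4 the expected value is 86%, with an estimated range from 62% to 100%.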

Compound 4, percent growth inhibition at one concentration: 90.9%
Compound 4: middle estimate off by 4.9 percentage points, on the low side; low and high end bracket the measured number.
By their numbers in this assay, from the lowest: compound 3; then compound 2; then compounds 1 and 4 (each within the scatter of the next).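

In this assay the series gains its first step that can be read at a single place: a number 0.3 percentage points higher from compound 1 to compound 4 (within the scatter), for phenyl in place of hydrogen on a saturated chain carbon bound to a saturated ring carbon. The methyl to benzyl difference therefore adds 6 heavy atoms and one six-membered aromatic ring at this place without a step beyond the scatter, so this place accepts a benzyl group on this read-out. Compound 1 at 90.6% and compound 4 at 90.9% both stand near the top of the read-out, where a result at one concentration cannot separate them, and no measurement on hand bears on this result.

On these data alone, whether this tolerance extends to other groups at this place, such as a primary amine, a carboxylic acid or a longer chain, remains open. Also open, as far as these compounds go, is whether compound 1 and compound 4 would stay within the scatter of each other at lower concentrations, where the read-out would have more room to separate them.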